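Cyclohexyl on the Ring Nitrogen: Expectation for Compound 3

The compounds below may be only part of what the source reports. "The series", "measured", "known", "first", "only" and "open" are said of these compounds alone.

The series is assessed in an assay on cell membranes for displacement of a labelled ligand from Cholecystokinin receptor type A (Rattus norvegicus), read by CCK-8 assay, with a stated time of 2 h; a lower number here means a stronger inhibitor, a higher number a weaker inhibitor. Compound 1 `CC(C)CN1C(=O)C=C(Cl)C1(O)c1ccccc1` gives 20 nM. Compound 2 `CC(C)(C)N1C(=O)C=C(Cl)C1(O)c1ccccc1`, which carries a tert-butyl group on the same nitrogen, gives 120 nM, so compound 2 stands as the higher of the two numbers, its nearest neighbour being compound 1 at a gap described by a 6.0-fold higher number from compound 1 to compound 2 (0.78 log units; beyond the scatter). Compound 3 `O=C1C=C(Cl)C(O)(c2ccccc2)N1C1CCCCC1` has not been measured; it differs from compound 2 in a single place: cyclohexyl in place of tert-butyl on an amide-type nitrogen in a ring. Among the compounds with values here, the only measured step that bears on this change is the one from isobutyl to tert-butyl, a 6.0-fold higher number from compound 1 to compound 2 (0.78 log units; beyond the scatter), which shows that the shape of the substituent on this nitrogen can move the number by a modest amount beyond the scatter. Since cyclohexyl shares a branched attachment with tert-butyl but also extends the substituent, a step back toward compound 1 is expected, but with little confidence. Compound 3 is therefore estimated at 70 nM, with a likely range from 20 nM to 250 nM, corresponding to an expected step of a 1.7-fold lower number from compound 2 to compound 3 (0.23 log units; within the scatter).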

Compound 3, half-maximal inhibitory concentration: > 10000 nM
Compound 3: no number, only a limit; the forecaster's own chance of this, stated with the estimate: 3%; at least 140-fold (2.15 log units) between middle value and limit.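

In this assay compound 3 stands at a limit of the assay and not at a number: the limit of > 10000 nM in this assay, at which 1 of the 3 values shown sits.

Cyclohexyl in place of tert-butyl on the amide-type nitrogen gives an at least 83-fold higher number from compound 2 to compound 3 (1.92 log units; beyond the scatter), and cyclohexyl in place of isobutyl gives an at least 500-fold higher number from compound 1 to compound 3 (2.69 log units; beyond the scatter), whereas the only earlier change at this position gave a 6.0-fold higher number from compound 1 to compound 2 (0.78 log units; beyond the scatter). The position therefore does more than shift the number by a modest amount: one carbon-only group, with no hydrogen-bond donors or acceptors and no net charge, takes the compound to the limit of the assay, so the swing at this nitrogen is far wider than the first two compounds showed.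

From the compounds shown here alone, the three compounds leave open whether this loss belongs to the six-membered ring itself or to the larger number of carbon atoms, and the true size of both new steps stays unknown with only a limit on one side. They also do not show how a cyclopropyl or cyclopentyl ring, an open n-hexyl chain or a benzyl group would read on this nitrogen, and so where between tert-butyl and cyclohexyl the number begins to climb.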